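Amide nitrogen substituents on the shared core

The source may report more compounds than this note shows. Statements on the series, on what has been measured and on what is new or still open speak of the compounds shown alone.

Compound 1 `NC(=O)c1cc(-c2ccc(NS(=O)(=O)c3cccc(Cl)c3Cl)cc2)nc2[nH]ncc12`: 236 nM
Compound 2 `CCNC(=O)c1cc(-c2ccc(NS(=O)(=O)c3cccc(Cl)c3Cl)cc2)nc2[nH]ncc12`: < 1920 nM

In an assay for inhibition of serine/threonine-protein kinase Sgk1 (Homo sapiens), with stated times of 30 min and 60 min, in the presence of a further agent that is not named here (on this read-out higher numbers stand for weaker inhibition and lower numbers for stronger inhibition), compound 1 gives 236 nM. For compound 2 the assay reports only a limit, < 1920 nM, so compound 2 stands at a limit and not at a number; this is the limit of < 1920 nM in this assay, at which 1 of the 2 values shown sits. The step that the limit leaves unreadable from compound 1 to compound 2 is therefore unreadable. Compound 3 `CN1CC(NC(=O)c2cc(-c3ccc(NS(=O)(=O)c4cccc(Cl)c4Cl)cc3)nc3[nH]ncc23)C1` differs from compound 2 by 1-methylazetidin-3-yl in place of ethyl on an amide-type nitrogen. Among the measured compounds shown here, no measured step bears on this change, and the one measured step is unreadable. For compound 3 the expected value is 350 nM, in the range 70 nM to 1800 nM, with an expected step that the limit leaves unreadable from compound 2 to compound 3 that cannot be sized against a limit.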

Compound 3, half-maximal inhibitory concentration: < 1 nM
Compound 3 was reported as a limit (the forecaster's own chance of this, stated with the estimate: 20%); at least 350-fold (2.54 log units) between middle value and limit.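

In this assay compound 3 is reported only as a limit, < 1 nM. Among the compounds shown here, the amide-type nitrogen therefore tolerates more than hydrogen: 1-methylazetidin-3-yl in place of hydrogen gives an at least 230-fold lower number from compound 1 to compound 3 (2.37 log units; beyond the scatter), the first readable step at this position. Steps to and from compound 2 cannot be read.

The compounds shown do not separate the contribution of the amine nitrogen from that of the four-membered ring. Cyclobutyl or a 2-(dimethylamino)ethyl chain on the same nitrogen would bear on that question.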